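The source may hold more compounds than are shown below. What is called first, only, known or untested is meant among the compounds shown, and "the series" means these compounds.

Measured compounds:
compound 1 `C[C@H](Nc1c(NCCCCCC(=O)NO)c(=O)c1=O)c1ccccc1`, 28000000 nM
compound 2 `Cc1ccccc1[C@H](C)Nc1c(NCCCCCC(=O)NO)c(=O)c1=O`, 47000000 nM
compound 3 `CC(CCCCC(=O)NO)Nc1c(Nc2ccccc2)c(=O)c1=O`, 46000000 nM

All three were tested in a physicochemical assay for solubility, with a stated time of 24 h, tested at 30 mg/mL; a higher number here means a more soluble compound, a lower number a less soluble compound. Compound 1 differs from compound 2 by one change, (methyl in place of hydrogen on an aromatic carbon), and that step measured a 1.7-fold higher number from compound 1 to compound 2 (0.22 log units; within the scatter). Compound 4 `Cc1ccc(Nc2c(NC(C)CCCCC(=O)NO)c(=O)c2=O)cc1` has not yet been measured; it differs from compound 3 by methyl in place of hydrogen on an aromatic carbon. Among the compounds with values here, this is the same kind of change as the one from compound 1 to compound 2, but not the same: in compound 2 the methyl sits ortho to a large group, in compound 4 it sits para to a large group. How the core of compound 3 differs from that of compound 1 is not broken down here. Because the earlier step gave a 1.7-fold higher number from compound 1 to compound 2 (0.22 log units; within the scatter), a similarly small step a 1.1-fold higher number from compound 3 to compound 4 (0.04 log units; within the scatter) is expected here. Compound 4 is therefore estimated at 50000000 nM, between 25000000 nM and 100000000 nM.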

Compound 4, solubility: 4900000 nM
Beside the measured number, compound 4's estimate is 10-fold (1.01 log units) above it, and the stated range ends above it.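

In this assay, methyl in place of hydrogen on an aromatic carbon gave a 1.7-fold higher number from compound 1 to compound 2 (0.22 log units; within the scatter), whereas on the core of compound 3, with the methyl para to a large group, it gave a 9.4-fold lower number from compound 3 to compound 4 (0.97 log units; beyond the scatter), so the small earlier step did not carry over to this core. The two steps differ in both the core and the methyl's place on the ring, and these compounds cannot show which of the two matters. No measurement shown here accounts for the larger step.

From the compounds shown here alone, it remains open whether a methyl para to a large group on the core of compound 1 would match compound 4. Also open, going by these compounds, is how a carboxylic acid or an amine at that ring position would read in this assay.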